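Moving the bromine around the ring of compound 1

The source may report more compounds than this note shows. Statements on the series, on what has been measured and on what is new or still open speak of the compounds shown alone.

The compounds share one core, a secondary amine carrying a propargyl group on a bicyclic scaffold, with a sulfur-linked benzyl arm that varies. Compound 1 is `C#CCNC1CCc2c(SCc3ccc(Br)cc3)cccc21`. In an assay on isolated protein for inhibition of Amine oxidase [flavin-containing] B (Homo sapiens) (on this read-out higher numbers stand for weaker inhibition and lower numbers for stronger inhibition), compound 1 gives 1310 nM, the lowest number among the three measured compounds. Compound 2 is `C#CCNC1CCc2c(SCc3ccc(C(F)(F)F)cc3)cccc21` and gives 9680 nM in this assay; that move, a 7.4-fold higher number from compound 1 to compound 2 (0.87 log units; beyond the scatter), came from putting trifluoromethyl in place of bromo on an aromatic carbon. Compound 3 is `C#CCNC1CCc2c(SCCc3cccc(Cl)c3)cccc21` and gives 82400 nM in this assay, but it differs from compound 1 in more than one place, so its number alone cannot be tied to a single change.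

Compound 4 is `C#CCNC1CCc2c(SCc3cccc(Br)c3)cccc21`. It differs from compound 1 by 3-bromophenyl in place of 4-bromophenyl on a saturated chain carbon bound to a sulfur. Going by the values given here, no measured step involves only a shift of a substituent around the ring: the one clean step, from compound 1 to compound 2, swaps the group itself, not its place. Nothing shown therefore argues for a step beyond the scatter in either direction. The expected step of a 1.2-fold higher number from compound 1 to compound 4 (0.09 log units; within the scatter) is accordingly small, and compound 4 is estimated to give 1600 nM in this assay, with a range from 500 nM to 5500 nM.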

Compound 4, half-maximal inhibitory concentration: > 100000 nM
Compound 4: no number, only a limit (the forecaster's own chance of this, stated with the estimate: 2%); middle value at least 62-fold (1.79 log units) away from the limit.
By their numbers in this assay, from the lowest: compound 1; then compound 2; then compound 3. At a limit, above all of these: compound 4.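

Replacing 4-bromophenyl with 3-bromophenyl on a saturated chain carbon bound to a sulfur leaves the atom count unchanged and only joins the bromine differently, yet in this assay it produces an at least 76-fold higher number from compound 1 to compound 4 (1.88 log units; beyond the scatter). For compound 4 the assay gives no exact number, only a limit: the limit of > 100000 nM in this assay, at which 1 of the 4 values shown sits. Among these compounds, then, where the bromine sits on the ring matters at least as much as which group is attached, since exchanging bromo for trifluoromethyl gave the smaller change of a 7.4-fold higher number from compound 1 to compound 2 (0.87 log units; beyond the scatter).

Going by these compounds, the shift is seen with bromo alone, so it remains open whether a methoxy group or an amine would show the same sharp loss when moved in the same way. It is also unclear whether any group at the 3-position of this ring can keep inhibition near that of compound 1, or whether the arm simply tolerates little there.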